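Aryl swap at the hydrazone carbon: compound 3 to compound 4

This account rests on a few compounds, and the source may have more. Where it says the series, first, only, none or still open, it means among the compounds named here.

Compound 1 `COc1cc2c(Oc3ccc(NC(=O)N/N=C/c4ccc([N+](=O)[O-])cc4)cc3F)ccnc2cc1OCCCN1CCCC1`: 310 nM
Compound 2 `COc1cc2c(Oc3ccc(NC(=O)N/N=C/c4ccc(C(F)(F)F)cc4)cc3F)ccnc2cc1OCCCN1CCCC1`: 810 nM
Compound 3 `COc1cc2c(Oc3ccc(NC(=O)N/N=C/c4ccc(F)cc4Cl)cc3F)ccnc2cc1OCCCN1CCCCC1`: 260 nM

In a functional assay on HT-29 cells (Homo sapiens) for cytotoxicity, read by MTT assay, with a stated time of 72 h (a lower number here means a stronger inhibitor, a higher number a weaker inhibitor), compound 3 gives the lowest of the three numbers shown. Its nearest neighbour is compound 1, whose value sits within the scatter of that of compound 3, while compound 2 lies beyond the scatter from both. Compound 4 `COc1ccc(/C=N/NC(=O)Nc2ccc(Oc3ccnc4cc(OCCCN5CCCCC5)c(OC)cc34)c(F)c2)c(OC)c1` differs from compound 3 in one place: 2,4-dimethoxyphenyl in place of 2-chloro-4-fluorophenyl on a carbon with a double bond to nitrogen.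

Among the measured compounds shown here, no measured step covers this change directly. For the measured compounds named here, the only step available, a 2.6-fold higher number from compound 1 to compound 2 (0.42 log units; beyond the scatter), shows that changing the substituent on the aryl ring attached to the hydrazone carbon moves the number modestly, in that case upward. Replacing two halogens by two methoxy groups is a larger change than that one, with no measured guide to its direction, so a modest step in either direction is possible and a weakening is weighted slightly. The expected step is a 1.9-fold higher number from compound 3 to compound 4 (0.28 log units; within the scatter). Compound 4 is expected to give 500 nM in this assay, with a range from 150 nM to 1700 nM.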

Compound 4, half-maximal inhibitory concentration: 1600 nM
Beside the measured number, compound 4's estimate is 3.2-fold (0.51 log units) below it; the measured number falls inside the stated range.
By their numbers in this assay, from the lowest: compounds 3 and 1 (each within the scatter of the next); then compounds 2 and 4 (each within the scatter of the next).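

In this assay, the swap at the carbon with a double bond to nitrogen gives a 6.2-fold higher number from compound 3 to compound 4 (0.79 log units; beyond the scatter), so exchanging 2-chloro-4-fluorophenyl for 2,4-dimethoxyphenyl moves the number upward by a measured step beyond the scatter. Among the compounds shown here, until now the only step on this aryl ring was a 2.6-fold higher number from compound 1 to compound 2 (0.42 log units; beyond the scatter), a swap of one substituent on the ring, whereas this change replaces two halogens with two methoxy groups at once and shows that this exchange also weakens the compound in this assay. Nothing measured here explains the step.

The compounds shown leave open whether a single methoxy group, or the removal of only the chlorine or only the fluorine, would carry this step. They also leave open how a ring bearing an amine or a carboxylic acid would read in this assay.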